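This account rests on a few compounds, and the source may have more. Where it says the series, first, only, none or still open, it means among the compounds named here.

Among the compounds with values here, in a functional assay on K562 cells (Homo sapiens) for inhibition, read by trypan blue exclusion, with a stated time of 72 h (on this read-out higher numbers stand for weaker inhibition and lower numbers for stronger inhibition), compound 3 (`Cn1c(=O)c(S(=O)(=O)c2ccc(F)cc2)cc2cnc(Nc3ccc4[nH]ccc4c3)nc21`) gives 200 nM, the lowest number of the three measured so far. Compound 1 (`Cn1c(=O)c(S(=O)(=O)c2ccc(F)cc2)cc2cnc(Nc3ccc4occc4c3)nc21`) gives 5000 nM, and compound 2 (`Cn1c(=O)c(S(=O)(=O)c2ccc(F)cc2)cc2cnc(Nc3ccc4cc[nH]c4c3)nc21`) gives 10000 nM. Compound 4 (`Cn1c(=O)c(S(=O)(=O)c2ccc(F)cc2)cc2cnc(Nc3ccc4[nH]cnc4c3)nc21`) has 1H-benzimidazol-5-yl in place of 1H-indol-5-yl on a nitrogen on an aromatic ring. Within the data shown here, two measured steps bear on this change, both large: a 25-fold lower number from compound 1 to compound 3 (1.40 log units; beyond the scatter) and a 50-fold lower number from compound 2 to compound 3 (1.70 log units; beyond the scatter). In both, the number falls on arrival at 1H-indol-5-yl, so leaving that group is expected to raise it. Neither step tests 1H-benzimidazol-5-yl itself, so a smaller rise is assumed, with wide uncertainty. The expected change is a 5.0-fold higher number from compound 3 to compound 4 (0.70 log units; beyond the scatter), towards weaker inhibition. Compound 4 is estimated at 1000 nM, with an expected range of 250 nM to 5000 nM.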

Compound 4, half-maximal inhibitory concentration: 10000 nM
Estimate against measurement, compound 4: 10-fold (1.00 log units) below; measured number outside the range, above it.
By their numbers in this assay, from the lowest: compound 3; then compounds 1, 2 and 4 (each within the scatter of the next).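

Replacing 1H-indol-5-yl with 1H-benzimidazol-5-yl keeps the hydrogen-bond donor and adds a hydrogen-bond acceptor, yet this one change on the nitrogen gives a 50-fold higher number from compound 3 to compound 4 (1.70 log units; beyond the scatter) and removes the advantage of compound 3. Compound 4 falls in with the two weaker compounds, showing no change at the digits printed from compound 2 to compound 4 (within the scatter) and a 2.0-fold higher number from compound 1 to compound 4 (0.30 log units; within the scatter), so compound 3 alone stands apart among the four. Nothing available explains this loss.

From the compounds shown here alone, it remains open whether 1H-indol-5-yl is uniquely favoured at this position. A 1H-indazol-5-yl group or a plain phenyl group would help to test this.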